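Notes on the series: compound 4 and its cyclohexyl group

The compounds below may be only part of what the source reports. "The series", "measured", "known", "first", "only" and "open" are said of these compounds alone.

Measured so far in an ADME assay on RAW264.7 cells (Mus musculus) for cytotoxicity, read by MTT assay, with a stated time of 24 h; a lower number here means that less compound is tolerated, a higher number that more compound is tolerated:
compound 1, `CC/C=C\C[C@H]1C(=O)C=C[C@H]1CC(=O)Oc1ccccc1`, gives 158 uM
compound 2, `CC/C=C\C[C@H]1C(=O)C=C[C@H]1CC(=O)Oc1ccc(O)cc1`, gives 49 uM
compound 3, `CC/C=C\C[C@H]1C(=O)C=C[C@H]1CC(=O)OCCOC`, gives 160 uM

Compound 3 gives the highest of the three numbers in this assay, but its gap to compound 1 is within the scatter (a 1.0-fold higher number from compound 1 to compound 3 (0.01 log units; within the scatter)), and only compound 2 sits clearly apart from it (a 3.3-fold higher number from compound 2 to compound 3 (0.51 log units; beyond the scatter)). Compound 4, `CC/C=C\C[C@H]1C(=O)C=C[C@H]1CC(=O)OC1CCCCC1`, differs from compound 3 on an oxygen next to a carbonyl group: cyclohexyl in place of 2-methoxyethyl on an oxygen next to a carbonyl group.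

For the measured compounds named here, two measured steps concern this same oxygen. Phenyl against 2-methoxyethyl gave no step beyond the scatter, a 1.0-fold higher number from compound 1 to compound 3 (0.01 log units; within the scatter). 4-Hydroxyphenyl against 2-methoxyethyl gave a modest step, a 3.3-fold higher number from compound 2 to compound 3 (0.51 log units; beyond the scatter), while compound 1 and compound 2, which differ only by hydroxy in place of hydrogen on an aromatic carbon, are separated by a 3.2-fold lower number from compound 1 to compound 2 (0.51 log units; beyond the scatter). No cyclohexyl group has been measured anywhere in the series, so the expectation rests on compound 1 and compound 3 giving the same number with unlike groups at this oxygen. Compound 4 is therefore expected to stay close to compound 3, with an expected step of a 1.1-fold lower number from compound 3 to compound 4 (0.06 log units; within the scatter). Compound 4 is estimated at 140 uM, with a range from 70 uM to 280 uM.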

Compound 4, half-maximal toxic concentration: 31 uM
The estimate for compound 4 lay 4.5-fold (0.65 log units) above the measured number; measured number below the stated range.
By their numbers in this assay, from the lowest: compounds 4 and 2 (each within the scatter of the next); then compounds 1 and 3 (each within the scatter of the next).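

In this assay the oxygen next to a carbonyl group turns out not to be indifferent to what it carries, even without a hydroxy group: cyclohexyl in place of 2-methoxyethyl gives a 5.2-fold lower number from compound 3 to compound 4 (0.71 log units; beyond the scatter) and cyclohexyl in place of phenyl gives a 5.1-fold lower number from compound 1 to compound 4 (0.71 log units; beyond the scatter), so the matching numbers of compound 1 and compound 3 did not describe this position as a whole. Cyclohexyl in place of 4-hydroxyphenyl gives a 1.6-fold lower number from compound 2 to compound 4 (0.20 log units; within the scatter), which places two unlike rings at one level, while compound 1 goes against any reading that a ring alone sets the number, since its phenyl stays level with the open chain of compound 3. Nothing available on these compounds accounts for the split into these two levels.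

Open, going by these compounds, is whether the low number of compound 4 belongs to cyclohexyl in particular or to saturated carbon groups at this oxygen generally, which cyclopentyl, an open hexyl chain or a tetrahydropyranyl ring would help to separate. Also open, on these data alone, is whether the ester oxygen itself matters, a question that an amide nitrogen carrying the same cyclohexyl group would address.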